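From a 4-bromophenyl amide to a 3-(methoxycarbonyl)phenyl amide

The source may report more compounds than this note shows. Statements on the series, on what has been measured and on what is new or still open speak of the compounds shown alone.

Compound 2 `CN(C)C(=O)c1cc2cnc(Nc3ccc(NC(=O)C4(C(=O)Nc5ccc(Br)cc5)CC4)cc3)nc2n1C1CCCC1` stands lowest of the three measured compounds in a functional assay on A549 cells (Homo sapiens) for inhibition, read by CCK-8 assay, with a stated time of 72 h, tested at 1 uM (a lower number here means less inhibition of growth, a higher number more inhibition of growth at the concentration tested), where compound 2 gives -6.6%. Compound 1 `CN(C)C(=O)c1cc2cnc(Nc3ccc(NC(=O)C4(C(=O)Nc5ccccc5F)CC4)cc3)nc2n1C1CCCC1` gives 79.1%, and compound 3 `CN(C)C(=O)c1cc2cnc(Nc3ccc(NC(=O)C4(C(=O)Nc5cccc(Br)c5)CC4)cc3)nc2n1C1CCCC1` gives 20.2%; the step of a number 85.7 percentage points lower from compound 1 to compound 2 (beyond the scatter) is large, and the step of a number 26.8 percentage points higher from compound 2 to compound 3 (beyond the scatter) is modest. Compound 4 `COC(=O)c1cccc(NC(=O)C2(C(=O)Nc3ccc(Nc4ncc5cc(C(=O)N(C)C)n(C6CCCC6)c5n4)cc3)CC2)c1` differs from compound 2 by 3-(methoxycarbonyl)phenyl in place of 4-bromophenyl on an amide-type nitrogen. The measured step of a number 26.8 percentage points higher from compound 2 to compound 3 (beyond the scatter) bears on this most directly: it too replaces the 4-bromophenyl with a differently substituted phenyl. Among the compounds with values here, the exchange of bromine for methoxycarbonyl has no measured counterpart. A modest rise is therefore expected for compound 4, namely a number 26.6 percentage points higher from compound 2 to compound 4 (beyond the scatter). Compound 4 is estimated at 20%, within -10% to 50%.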

Compound 4, percent growth inhibition at one concentration: 10.5%
Estimate against measurement, compound 4: 9.5 percentage points above; low and high end bracket the measured number.
By their numbers in this assay, from the lowest: compound 2; then compounds 4 and 3 (each within the scatter of the next); then compound 1.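

Replacing the 4-bromophenyl with 3-(methoxycarbonyl)phenyl on the amide-type nitrogen gives a number 17.1 percentage points higher from compound 2 to compound 4 (beyond the scatter) and so only a modest gain, while a number 68.6 percentage points lower from compound 1 to compound 4 (beyond the scatter) shows that the new group stays far short of the 2-fluorophenyl. Methoxycarbonyl in place of bromo on an aromatic carbon, an exchange the earlier compounds did not cover, gives a number 9.7 percentage points lower from compound 3 to compound 4 (within the scatter) and so no readable change. No evidence on hand accounts for these differences. Still open, as far as these compounds go, is how a phenyl carrying an amine or a carboxylic acid would compare with compound 4 and compound 1.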